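Amide series on breast-cancer cell growth: aryl to acetyl

The compounds below may be only part of what the source reports. "The series", "measured", "known", "first", "only" and "open" are said of these compounds alone.

Measured compounds:
compound 1, `O=C(Nc1ccccc1C(F)(F)F)C1CCc2ccccc2N1C(=O)c1cccc(Cl)c1`: 288 nM
compound 2, `O=C(Nc1ccccc1C(F)(F)F)C1CCc2ccccc2N1C(=O)c1ccc(Cl)cc1`: 533 nM

Going by the values given here, in a functional assay on MDA-MB-231 cells (Homo sapiens) for cytotoxicity, read by sulforhodamine B assay, with a stated time of 72 h (on this read-out lower numbers stand for stronger inhibition of growth and higher numbers for weaker inhibition of growth), compound 2 gives the higher of the two numbers, and its only neighbour is compound 1, with a 1.9-fold higher number from compound 1 to compound 2 (0.27 log units; within the scatter); that gap lies within the scatter, so no order between the two can be claimed.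

Compound 3, `CC(=O)N1c2ccccc2CCC1C(=O)Nc1ccccc1C(F)(F)F`, is not yet measured. Against compound 2 it shows (methyl in place of 4-chlorophenyl on a carbonyl carbon). Among the compounds with values here, the single measured step moves a chlorine around the same ring and says nothing about removing the ring altogether, so no measured step bears directly on this change. With an aryl group gone from the carbonyl on the ring nitrogen, a weaker result than compound 2 is expected, though with wide uncertainty; the expected step is a 2.8-fold higher number from compound 2 to compound 3 (0.45 log units; beyond the scatter). Compound 3 is estimated at 1500 nM, in the range 400 nM to 6000 nM.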

Compound 3, concentration for 50% growth inhibition: > 80000 nM
Compound 3 gave a limit, no number (the forecaster's own chance of this, stated with the estimate: 15%); middle value at least 53-fold (1.72 log units) from the limit.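

In this assay, compound 3 gives a limit and not a number: the limit of > 80000 nM in this assay, at which 1 of the 3 values shown sits.

Methyl in place of 4-chlorophenyl on a carbonyl carbon gives an at least 150-fold higher number from compound 2 to compound 3 (2.17 log units; beyond the scatter), and methyl in place of 3-chlorophenyl at the same place gives an at least 270-fold higher number from compound 1 to compound 3 (2.44 log units; beyond the scatter). Within these three compounds, what sits on this carbonyl therefore counts for far more than where the chlorine sits on the ring, since the chlorine move stays within the scatter.

The compounds shown leave open whether the chlorine is needed at all, or whether any ring on this carbonyl would serve. Plain phenyl, cyclohexyl or a longer chain such as butyl in the same place would separate these possibilities and fill the wide gap between the chlorophenyl groups and methyl.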